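Thiourea series: aryl versus benzyl on the thiourea nitrogen

The compounds below may be only part of what the source reports. "The series", "measured", "known", "first", "only" and "open" are said of these compounds alone.

Among the compounds with values here, compound 2 `O=c1ccc(-c2ccccc2)nn1CCCCNC(=S)NCc1ccccc1` is the lower of the two compounds measured so far in a functional assay on the whole organism with Rattus norvegicus as the target, at a dose of 100 mg/kg; a higher number here means more inhibition at the dose given (going by the name of the read-out), a lower number less inhibition: compound 2 gives 5.4%, while compound 1 `O=c1ccc(-c2ccccc2)nn1CCCCNC(=S)Nc1ccc(Cl)cc1` gives 43.2%. Within the data shown here, the one step on record, a number 37.8 percentage points lower from compound 1 to compound 2 (beyond the scatter), is the reverse of the type of change now in view: an aryl group on the thiourea nitrogen gave way to benzyl and the inhibition fell steeply.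

Compound 3 `O=c1ccc(-c2ccccc2)nn1CCCCNC(=S)Nc1cccc2ccccc12` has not been measured. The change from compound 2 is naphthalen-1-yl in place of benzyl on an amide-type nitrogen. This returns an aryl group directly on the amide-type nitrogen, as in compound 1, so the step of a number 37.8 percentage points lower from compound 1 to compound 2 (beyond the scatter) bears on it most directly, and a rise beyond the scatter is expected, roughly undoing that loss. Whether a naphthalen-1-yl matches a 4-chlorophenyl cannot be told from these two compounds alone, so the range is kept wide.

Compound 3 is therefore expected to rise by about a number 26.6 percentage points higher from compound 2 to compound 3 (beyond the scatter). The estimate for compound 3 in this assay is 32%, within 10% to 55%.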

Compound 3, a percentage reported as inhibition, in the whole organism at one dose (the size of the read-out at that dose, not a potency): 42.3%
Estimate against measurement, compound 3: 10.3 percentage points below, within the range that was stated.
By their numbers in this assay, from the lowest: compound 2; then compounds 3 and 1 (each within the scatter of the next).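

Thiourea series: notes on the naphthalen-1-yl result

In this assay, naphthalen-1-yl in place of benzyl on the amide-type nitrogen gives a number 36.9 percentage points higher from compound 2 to compound 3 (beyond the scatter), so the low reading for benzyl now stands against two different aryl groups and no longer rests on one comparison. With 4-chlorophenyl replaced by naphthalen-1-yl, the change is a number 0.9 percentage points lower from compound 1 to compound 3 (within the scatter), so these two aryl groups cannot be told apart in this read-out, although one brings a single six-membered aromatic ring and the other brings two; among these compounds, an aryl group directly on this nitrogen goes with the higher readings, and none of the three goes against this. Nothing on hand explains why benzyl and the two aryl groups differ in this way.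

Still open, from the compounds shown here alone, is how unsubstituted phenyl, or a phenyl ring carrying an amine or a carboxylic acid, would read on this nitrogen, and whether 2-phenylethyl, with its longer chain, would stay as low as benzyl. These readings come from a single dose, so they leave open whether compound 1 and compound 3 would also match across a range of doses.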